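The source may report more compounds than this note shows. Statements on the series, on what has been measured and on what is new or still open speak of the compounds shown alone.

In a functional assay (aorta) for inhibition, with Rattus norvegicus as the target (on this read-out lower numbers stand for an effect already at smaller amounts and higher numbers for an effect only at larger amounts of compound), three compounds have been measured so far:
compound 1, `O=C1C(Nc2ccc(F)c(F)c2)=CC(=O)c2ncccc21`, gives 251 nM;
compound 2, `O=C1C(Nc2ccc(F)c(F)c2F)=CC(=O)c2ncccc21`, gives 937 nM;
compound 3, `O=C1C=C(Nc2ccccc2)C(=O)c2cnccc21`, gives 439 nM.

Compound 2 arises from compound 1 by fluoro in place of hydrogen on an aromatic carbon, placed on an aromatic carbon ortho to a fluoro group, ortho to a large group and meta to a fluoro group, and this change gave a 3.7-fold higher number from compound 1 to compound 2 (0.57 log units; beyond the scatter). Compound 3 rests on another core; the difference between the cores of compound 1 and compound 3 is not broken down here, and in this assay their two numbers lie within the scatter of each other. Compound 4, `O=C1C=C(Nc2cccc(F)c2)C(=O)c2cnccc21`, is not yet measured. It differs from compound 3 by fluoro in place of hydrogen on an aromatic carbon, here on an aromatic carbon meta to a large group, so it is the same kind of change as that from compound 1 to compound 2, though not the same, as the surroundings of the place differ. A smaller rise is expected from compound 3 to compound 4, a 1.5-fold higher number from compound 3 to compound 4 (0.17 log units; within the scatter), because the earlier step of a 3.7-fold higher number from compound 1 to compound 2 (0.57 log units; beyond the scatter) was only modest and the single measured case cannot be carried over unchanged. Compound 4 is therefore expected to give about 650 nM in this assay, most likely between 280 nM and 1500 nM.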

Compound 4, half-maximal effective concentration: 562 nM
Estimate against measurement, compound 4: 1.2-fold (0.06 log units) above; measured number inside the range.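

In this assay the replacement of hydrogen by fluoro gave a 1.3-fold higher number from compound 3 to compound 4 (0.11 log units; within the scatter) and, set beside the earlier step, the same change does not have the same size on the two cores: the same change on two cores in this assay, a 3.7-fold higher number (0.57 log units; beyond the scatter) from compound 1 to compound 2 and a 1.3-fold higher number (0.11 log units; within the scatter) from compound 3 to compound 4, 2.9-fold (0.46 log units) apart, beyond the scatter of two such steps

A step read on one core therefore cannot be carried over at its full size to the other in this series. This does not show that the core alone sets the size, as the fluoro enters at a different place in each pair and compound 1 already bears fluoro groups on that ring, while compound 3 bears none.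

As far as these compounds go, it remains open how either core would respond to other groups on this ring, such as a methoxy group, an amine or a carboxylic acid. From the compounds shown here alone, it also remains open whether the fluoro step at one given place would match on both cores.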